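Phenyl for Ethyl on the Amide Carbonyl

The source may hold more compounds than are shown below. What is called first, only, known or untested is meant among the compounds shown, and "the series" means these compounds.

This short series shares one core that carries an amide. In an ADME assay on RD cells (Homo sapiens) for cytotoxicity, read by microscopy (a higher number here means that more compound is tolerated, a lower number that less compound is tolerated), compound 1 `CC(=O)c1cccc(Nc2nc(-c3sc(NC(=O)c4ccc(I)cc4)nc3C)cs2)c1` is recorded as "not determined" (no result reported), so it contributes no number. Compound 2 `CCC(=O)Nc1nc(C)c(-c2csc(Nc3cccc(C(C)=O)c3)n2)s1` gives 6370 nM in this assay; this is the only number shown, and with no second measured value there is no ranking and no step between measured compounds to draw on. Compound 3 `CC(=O)c1cccc(Nc2nc(-c3sc(NC(=O)c4ccccc4)nc3C)cs2)c1` is still to be measured. It differs from compound 2 in a single place (phenyl in place of ethyl on a carbonyl carbon), which cut one bond further out reads propanoylamino to benzamido, on the carbonyl carbon whose other neighbour is an amide-type nitrogen. Among the compounds with values here, no measured pair shows what this change does here. The account expects a small step, a 1.3-fold lower number from compound 2 to compound 3 (0.11 log units; within the scatter), toward less compound tolerated, and not clearly beyond the scatter. Compound 3 is therefore estimated at 5000 nM, with a range from 2000 nM to 15000 nM.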

Compound 3, half-maximal cytotoxic concentration: 11800 nM
Compound 3: the middle estimate sits 2.4-fold (0.37 log units) below what was measured, within the range that was stated.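

Within the data shown here, this is the first measured pair, and it puts a size on the change: in this assay, phenyl in place of ethyl on a carbonyl carbon gives a 1.9-fold higher number from compound 2 to compound 3 (0.27 log units; within the scatter) and so does not separate the two compounds. At this place, then, a six-membered aromatic ring of carbon only can stand where the ethyl stood without a step beyond the scatter in how much compound is tolerated. Nothing available explains why the two groups read alike.

The compounds shown do not tell how a longer chain, an amine or a carboxylic acid at this place would read in this assay. Nor can the effect of iodine on the phenyl be judged, as compound 1 is recorded as "not determined" (no result reported) and offers no comparison.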